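From Hydroxy to (4-Chlorophenyl)amino on a Carbonyl Carbon

The source may report more compounds than this note shows. Statements on the series, on what has been measured and on what is new or still open speak of the compounds shown alone.

Among the compounds with values here, in a functional assay on Bel-7402 cells (Homo sapiens) for inhibition, read by MTT assay, with a stated time of 24 h, tested at 10 ug/mL (on this read-out lower numbers stand for less inhibition of growth and higher numbers for more inhibition of growth at the one concentration tested), compound 1 `CC(=O)SCCC(CCCCC(=O)O)SC(C)=O` gives 9.22%, the lower of the two numbers measured so far. Compound 2 `O=C(CCCCC1CCSS1)Nc1ccc(Br)cn1` gives 24.5%, higher by more than the usual scatter. Compound 3 `CC(=O)SCCC(CCCCC(=O)Nc1ccc(Cl)cc1)SC(C)=O` carries (4-chlorophenyl)amino in place of hydroxy on a carbonyl carbon. Within the data shown here, compound 2, at 24.5%, also has an amino group bearing a ring on a carbonyl carbon, and this single comparison is the only guide. A rise in this assay beyond the scatter is therefore expected, with an estimated a number 16.8 percentage points higher from compound 1 to compound 3 (beyond the scatter). For compound 3 the estimated value is 26%, with an expected range of 10% to 48%.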

Compound 3, percent growth inhibition at one concentration: 5.78%
Estimate against measurement, compound 3: 20.2 percentage points above; the measured number lies below the stated range.
By their numbers in this assay, from the lowest: compounds 3 and 1 (each within the scatter of the next); then compound 2.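

Exchanging hydroxy for (4-chlorophenyl)amino on a carbonyl carbon adds an aromatic ring at this position, yet in this assay the step reads a number 3.4 percentage points lower from compound 1 to compound 3 (within the scatter). At this one concentration, the two groups therefore cannot be told apart at this position. Nothing available here explains this result. On these data alone, it remains open whether a plain amino group or a methoxy group on the same carbonyl carbon would give a number clearly different from that of compound 1.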